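The source may report more compounds than this note shows. Statements on the series, on what has been measured and on what is new or still open speak of the compounds shown alone.

Measured compounds:
compound 1 `CC[C@H](C)[C@H](N)CN(C(=O)[C@@H]1C[C@H]1c1ccc(OC)cc1)c1ccc(-c2ccccc2)cc1` — in a functional assay for agonist activity at G protein-coupled receptor 88 (Homo sapiens), read by HTRF and cAMP accumulation (a higher number here means that more compound is needed for the effect, a lower number that less compound is needed), compound 1 gives > 25000 nM, which is a limit of the assay and not a number.
compound 2 `CC[C@H](C)[C@H](N)CN(C(=O)[C@@H]1C[C@H]1c1ccc(F)cc1)c1ccc(-c2ccccc2)cc1` — in this assay compound 2 gives 600 nM.

Compound 2 thus stands as the only numerical result in this assay; the other result is a limit (the limit of > 25000 nM in this assay, at which 1 of the 2 values shown sits). Within the data shown here, the one measured step, an at least 41-fold lower number from compound 1 to compound 2 (1.61 log units; beyond the scatter), is large. Compound 3 `CC[C@H](C)[C@H](N)CN(C(=O)[C@@H]1C[C@H]1c1cccc(C#N)c1)c1ccc(-c2ccccc2)cc1` carries 3-cyanophenyl in place of 4-fluorophenyl on a saturated ring carbon. This change touches the same aryl ring as the measured step but is not the same kind of change: the fluorine leaves and a nitrile enters elsewhere on the ring, rather than one group replacing another on an aromatic carbon. Among the measured compounds shown here, the measured step therefore shows only that substitution on this ring can move this assay a great deal, not which way this change goes. An increase in the number is expected, a 2.5-fold higher number from compound 2 to compound 3 (0.40 log units; beyond the scatter), with wide uncertainty. For compound 3 the estimate is 1500 nM, in the range 300 nM to 10000 nM.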

Compound 3, half-maximal effective concentration: 1600 nM
Beside the measured number, compound 3's estimate is 1.1-fold (0.03 log units) below it, and the stated range covers the measured number.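

In this assay, the change from 4-fluorophenyl to 3-cyanophenyl on the saturated ring carbon gives a 2.7-fold higher number from compound 2 to compound 3 (0.43 log units; beyond the scatter), so a measurable number survives a replacement of the fluorine-bearing aryl group by a nitrile-bearing one. The change from 4-methoxyphenyl to 3-cyanophenyl at the same place gives an at least 15-fold lower number from compound 1 to compound 3 (1.19 log units; beyond the scatter), so the loss seen with 4-methoxyphenyl is not shared by every other substituted phenyl here. Compound 1 stands at a limit and not a number: the limit of > 25000 nM in this assay, at which 1 of the 3 values shown sits.

The step to compound 3 changes both the substituent and where it sits on the aryl ring, so the share of each cannot be read. From the compounds shown here alone, how 4-cyanophenyl, 3-fluorophenyl or an aminophenyl group would behave in this assay remains open.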